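Stilbene ethers with basic side chains: amide for hydroxyl

A few compounds are considered here, and "the series" means these few. Any claim that something is new, unique, unknown or untested is made for them only; others in the source may bear on it.

Working notes on a small set of stilbene ethers carrying a four-carbon chain to a cyclic amine, tested in a functional assay on the whole organism with Mus musculus as the target, in the maximal electroshock model, at a dose of 50 mg/kg by the oral route; a lower number here means less inhibition, a higher number more inhibition at the dose given (going by the name of the read-out). Compound 1 `OC1CCN(CCCCOc2ccccc2/C=C/c2ccccc2)CC1` gives 0% in this assay, the lowest of the two numbers at hand. Compound 2 `CN(C)CCCCOc1ccc(/C=C/c2ccccc2)cc1` gives 12.5% in this assay, a number higher than that of compound 1 by a margin beyond the usual scatter. Within the data shown here, no single-change pair among the measured compounds is available, so no measured step can be read.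

Compound 3 `NC(=O)C1CCCN(CCCCOc2ccccc2/C=C/c2ccccc2)C1` has not yet been measured. It differs from compound 1 in one place: 3-carbamoylpiperidin-1-yl in place of 4-hydroxypiperidin-1-yl on a saturated chain carbon, four bonds along the chain from an oxygen on an aromatic ring. The basic cyclic amine and the remaining part of compound 1 are kept. Among the measured compounds shown here, with no measured step on record for such a change, the expected step from compound 1 to compound 3 is a small one upward, a number 8 percentage points higher from compound 1 to compound 3 (within the scatter), which is not beyond the scatter. Compound 3 is therefore expected to give about 8% in this assay, estimated to fall between 0% and 30%.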

Compound 3, a percentage reported as inhibition, in the whole organism at one dose (the size of the read-out at that dose, not a potency): 0%
Compound 3: middle estimate off by 8 percentage points, on the high side; measured number inside the range.
By their numbers in this assay, from the lowest: compounds 1 and 3 (each within the scatter of the next); then compound 2.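

In this assay, among these compounds, 3-carbamoylpiperidin-1-yl in place of 4-hydroxypiperidin-1-yl on a saturated chain carbon, four bonds along the chain from an oxygen on an aromatic ring, gives no change at the digits printed from compound 1 to compound 3 (within the scatter), the first step that can be read at this position. The entering group has 9 heavy atoms against 7 and a double bond outside aromatic rings, with the same hydrogen-bond donor and acceptor counts, and the two compounds cannot be told apart at this dose; as compound 1 already reads 0%, the step can show no loss, only the absence of a gain for this one exchange. Nothing measured bears on why this exchange gives no gain.

Open, going by these compounds, is whether morpholin-4-yl, 4-methylpiperazin-1-yl or a plain dimethylamino group at this place on the core of compound 1 would read beyond the scatter of compound 1. Also open, on these data alone, is whether a carboxylic acid in place of the carbamoyl group, or a longer chain to the same 3-carbamoylpiperidin-1-yl, would give a reading above the bottom of this scale.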